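Alkyl variation on a shared core, three limits so far

The compounds below may be only part of what the source reports. "The series", "measured", "known", "first", "only" and "open" are said of these compounds alone.

Compound 1 `Cc1nc2nc(-c3ccccc3)cc(C(F)(F)F)c2c(=O)n1Cc1cn(CCC(F)(F)C(F)(F)C(F)(F)C(F)(F)C(F)(F)C(F)(F)F)nn1` opens the series. In a functional assay on THP-1 cells (Homo sapiens) for cytotoxicity, read by MTT assay, with a stated time of 24 h (a lower number here means a stronger inhibitor, a higher number a weaker inhibitor), compound 1 gives > 200 ug/mL, which is a limit of the assay and not a number. Compound 2 `CCc1nc2nc(-c3ccccc3)cc(C(F)(F)F)c2c(=O)n1Cc1cn(CCC(F)(F)C(F)(F)C(F)(F)C(F)(F)C(F)(F)C(F)(F)F)nn1` differs from compound 1 by methyl in place of hydrogen on a saturated chain carbon bound to an aromatic carbon. In this assay compound 2 gives > 200 ug/mL, again a limit. The step that the two limits leave unreadable from compound 1 to compound 2 therefore has no readable size. Compound 3 `CCc1nc2nc(-c3ccccc3)cc(C(F)(F)F)c2c(=O)n1Cc1cn(CCC(F)(F)C(F)(F)C(F)(F)C(F)(F)C(F)(F)C(F)(F)C(F)(F)C(F)(F)F)nn1` differs from compound 2 by 1,1,2,2,2-pentafluoroethyl in place of fluoro on a saturated chain carbon bound to two fluorine atoms and a saturated chain carbon. In this assay compound 3 gives > 200 ug/mL, also a limit. The step that the two limits leave unreadable from compound 2 to compound 3 is likewise unreadable. The difference between the cores of compound 1 and compound 3 is not broken down here. Every measured value sits at the limit of > 200 ug/mL in this assay, at which 3 of the 3 values shown sit.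

Compound 4 `CC(C)c1nc2nc(-c3ccccc3)cc(C(F)(F)F)c2c(=O)n1Cc1cn(CCC(F)(F)C(F)(F)C(F)(F)C(F)(F)C(F)(F)C(F)(F)C(F)(F)C(F)(F)F)nn1` is not yet measured; it differs from compound 3 by methyl in place of hydrogen on a saturated chain carbon bound to an aromatic carbon and a saturated chain carbon. This is the same kind of change as from compound 1 to compound 2, but the place differs: in compound 2 the carbon is bound to an aromatic carbon, in compound 4 to an aromatic carbon and a saturated chain carbon. The earlier step gave no size, so the only footing is that all three measured compounds sit at the limit of > 200 ug/mL in this assay, at which 3 of the 3 values shown sit. The expected step that the limit leaves unreadable from compound 3 to compound 4 is accordingly small and uncertain. Compound 4 is estimated at 250 ug/mL in this assay, with an expected range from 100 ug/mL to 1000 ug/mL, and a limit is again the likeliest outcome.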

Compound 4, half-maximal inhibitory concentration: 142 ug/mL
Compound 4: the middle estimate sits 1.8-fold (0.25 log units) above what was measured, within the range that was stated.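

In this assay, for the compounds shown here, the change of methyl in place of hydrogen, on a saturated chain carbon bound to an aromatic carbon and a saturated chain carbon, gives an at least 1.4-fold lower number from compound 3 to compound 4 (0.14 log units; that floor lies within the scatter), so the one readable step is only a floor and that floor does not clear the usual scatter. The same kind of change on the core of compound 1, on a saturated chain carbon bound to an aromatic carbon, cannot be read, like every other step between two limits, so no second size stands beside this one and carrying the change from one core to another is not shown. Only one compound in the series has a number, and the other three share a single limit, which allows no comparison of step sizes: the limit of > 200 ug/mL in this assay, at which 3 of the 4 values shown sit.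

Left open is whether a tert-butyl or cyclopropyl group in place of the isopropyl would move the reading away from that of compound 4 at 142 ug/mL, and whether isopropyl gives any readable step on the fluorinated chain of compound 2. Also open, on these data alone, is whether the step holds when an amine or a carboxylic acid stands at the end of the chain in place of the fluorinated tail.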